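The compounds below may be only part of what the source reports. "The series", "measured", "known", "first", "only" and "open" are said of these compounds alone.

Going by the values given here, in a functional assay on EC9706 cells (Homo sapiens) for antiproliferative activity, read by MTT assay, with a stated time of 72 h (a higher number here means a weaker inhibitor, a lower number a stronger inhibitor), compound 3 `O=C(N/N=C/c1ccccn1)c1cccc(S(=O)(=O)N2CCOCC2)c1` gives 44300 nM, the highest of the three numbers so far. Compound 1 `C/C(=N\NC(=O)c1cccc(S(=O)(=O)N2CCOCC2)c1)c1cc(Br)ccc1O` gives 24700 nM, which lies within the scatter of compound 3, while compound 2 `C/C(=N\NC(=O)c1cccc(S(=O)(=O)N2CCOCC2)c1)c1cccc(N)c1O` gives 3520 nM, far lower. Among the compounds with values here, the only measured step, a 7.0-fold lower number from compound 1 to compound 2 (0.85 log units; beyond the scatter), changes substituents on a 2-hydroxyphenyl ring and does not touch a pyridin-2-yl group. Compound 4 `COc1ccc(/C=N/NC(=O)c2cccc(S(=O)(=O)N3CCOCC3)c2)c(O)c1` differs from compound 3 by 2-hydroxy-4-methoxyphenyl in place of pyridin-2-yl on a carbon with a double bond to nitrogen. Within the data shown here, no measured step swaps pyridin-2-yl for a phenyl ring, so the change is judged only from compounds 1 and 2, both 2-hydroxyphenyl analogues, whose numbers sit at or well below that of compound 3. For compound 4 a move toward those numbers is expected, a 3.0-fold lower number from compound 3 to compound 4 (0.47 log units; beyond the scatter). Compound 4 is estimated at 15000 nM, within 4000 nM to 50000 nM.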

Compound 4, half-maximal inhibitory concentration: 1090 nM
For compound 4 the middle estimate is 14-fold (1.14 log units) above the measured one; measured number outside the range, below it.
By their numbers in this assay, from the lowest: compound 4; then compound 2; then compounds 1 and 3 (each within the scatter of the next).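

In this assay, the aryl group on a carbon with a double bond to nitrogen has a large effect: with 2-hydroxy-4-methoxyphenyl in place of pyridin-2-yl, the result is a 41-fold lower number from compound 3 to compound 4 (1.61 log units; beyond the scatter). Going by these compounds alone, earlier, the only measured step varied substituents on a 2-hydroxyphenyl ring; this one changes the ring itself. The swap replaces the ring and introduces hydroxy and methoxy together, and no evidence on the cause of the step is available.

As far as these compounds go, how much of the step belongs to the hydroxy and how much to the methoxy remains open. So does the effect of an unsubstituted phenyl, or of a dimethylamino group in place of the methoxy.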